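Ring-closed side chain: what to expect for compound 3

A few compounds are considered here, and "the series" means these few. Any claim that something is new, unique, unknown or untested is made for them only; others in the source may bear on it.

Compound 2 `CC(C)=CCn1nc(-c2cccnc2)c2ccccc2c1=O` gives 94% in an assay on isolated protein (Oryctolagus cuniculus) with Thromboxane-A synthase (Homo sapiens) as the target, tested at 1 uM; on this read-out higher numbers stand for more inhibition at the one concentration tested (going by the name of the read-out) and lower numbers for less inhibition; compound 1 `CCCn1nc(-c2cccnc2)c2ccccc2c1=O` gives 86%, and the two numbers sit within the scatter of each other, as the step of a number 8 percentage points higher from compound 1 to compound 2 (within the scatter) shows. Compound 3 `O=c1c2ccccc2c(-c2cccnc2)nn1C1CCCC1` is not yet measured; the change is cyclopentyl in place of 3-methylbut-2-en-1-yl on an aromatic nitrogen. Within the data shown here, the only step that bears on it is the exchange of the group on that same nitrogen, a number 8 percentage points higher from compound 1 to compound 2 (within the scatter), which stayed within the scatter. Among the measured compounds shown here, no measured step swaps a chain for a ring, so the expected step is a number 6 percentage points lower from compound 2 to compound 3 (within the scatter), nothing beyond the scatter. Compound 3 is estimated at 88%, between 70% and 97%.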

Compound 3, a percentage reported as inhibition, at one concentration (the size of the read-out at that concentration, not a potency): 97%
Compound 3: the middle estimate sits 9 percentage points below what was measured; measured number inside the range.
By their numbers in this assay, from the lowest: compounds 1, 2 and 3 (each within the scatter of the next, the first and the last beyond it).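

On an aromatic nitrogen, the step of a number 3 percentage points higher from compound 2 to compound 3 (within the scatter) shows that a closed cyclopentyl ring can replace the open 3-methylbut-2-en-1-yl without loss in this assay within this series. Against propyl, the step of a number 11 percentage points higher from compound 1 to compound 3 (beyond the scatter) is the first at this position to lie beyond the scatter, though it is modest. Nothing available gives a reason for either step.
The compounds shown leave open how a cyclohexyl ring, a longer chain or an amine on this nitrogen would read, and whether anything can replace the pyridin-3-yl group.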